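This account rests on a few compounds, and the source may have more. Where it says the series, first, only, none or still open, it means among the compounds named here.

Compound 1, `Cc1nc(N)sc1CCCN/C(N)=N/C(=O)N[C@H](C)c1ccccc1`: 17.8 nM
Compound 3, `Cc1nc(N)sc1CCCN/C(N)=N/C(=O)NC(C)c1ccccc1F`: 28.8 nM
Compound 2, `CCCNC(=O)/N=C(\N)Nc1cccc(-c2csc(N)n2)c1`: 5250 nM

In an assay on membranes from Sf9 cells for displacement of a labelled ligand from histamine H2 receptor (Homo sapiens), read by scintillation counting, with a stated time of 60 min (on this read-out higher numbers stand for weaker inhibition and lower numbers for stronger inhibition), compound 1 stands at the low end of the three numbers. Compound 3 sits within the usual scatter of compound 1, so the two cannot be told apart, while compound 2 lies far beyond the scatter and inhibits much more weakly. Compound 4, `Cc1nc(N)sc1CCCN/C(N)=N/C(=O)NCc1ccccc1`, keeps the core of compound 1 and differs only by hydrogen in place of methyl on a saturated chain carbon bound to an amide-type nitrogen and an aromatic carbon. Among the measured compounds shown here, no pair of measured compounds differs by this change, so its effect is unknown here. With a single small group removed near the amide, the step of a 1.7-fold higher number from compound 1 to compound 4 (0.23 log units; within the scatter) is expected to stay close to the scatter, if anything drifting slightly toward weaker inhibition. Compound 4 is therefore expected to give about 30 nM, with a range from 10 nM to 90 nM.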

Compound 4, inhibition constant: 69.2 nM
Compound 4: middle estimate off by 2.3-fold (0.36 log units), on the low side, within the range that was stated.
By their numbers in this assay, from the lowest: compounds 1 and 3 (each within the scatter of the next); then compound 4; then compound 2.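

In this assay, swapping the methyl for hydrogen, which turns 1-phenylethyl into benzyl, gives a 3.9-fold higher number from compound 1 to compound 4 (0.59 log units; beyond the scatter), a modest move toward weaker inhibition. Among the compounds shown here, this is the first direct sign that this saturated chain carbon is sensitive to change, since no earlier pair differed in one place, and here a single methyl is enough to shift the number beyond the scatter. Nothing measured here gives a reason for the shift.

From the compounds shown here alone, whether an ethyl or a hydroxymethyl group on this carbon would lower or raise the number remains open. So does how the mirror-image form of compound 1 would compare.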